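Swapping 1-hydroxyethyl for pyrazin-2-yl on a shared core

A few compounds are considered here, and "the series" means these few. Any claim that something is new, unique, unknown or untested is made for them only; others in the source may bear on it.

In an in vivo ADME assay on the whole organism (strain 129/SvEvBrd x C57BL/6) for pharmacokinetics, with Mus musculus as the target (a higher number here means that a larger share of the oral dose reaches the circulation, a lower number that a smaller share of the oral dose reaches the circulation), compound 3 `CC(O)c1nc([C@@H](O)[C@H](O)[C@H](O)CO)c[nH]1` gives 22%. Compound 2 `CCc1[nH]c(C(C)=O)nc1[C@@H](O)[C@H](O)[C@H](O)CO` gives 17.1%, which lies within the usual scatter of the value for compound 3. Compound 1 `CC(=O)c1cccc([C@@H](O)[C@H](O)[C@H](O)CO)n1` reaches 88%, far beyond that scatter, so compound 3 sits well under it and level with compound 2.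

The next compound to be tested is compound 4 `OC[C@@H](O)[C@@H](O)[C@H](O)c1c[nH]c(-c2cnccn2)n1`. It carries pyrazin-2-yl in place of 1-hydroxyethyl on an aromatic carbon, between two ring nitrogen atoms (pyrazin-2-yl in place of 1-hydroxyethyl on an aromatic carbon). The rest of the structure stays as it is in compound 3.

Among the compounds with values here, no two measured compounds differ in one place only, so no measured step guides this change. The best starting point is therefore compound 3 at 22%. The core of compound 1 differs from that of compound 3, so its high value cannot simply be carried over, but it does show that much larger numbers occur in this small set. The expected step is a number 8 percentage points higher from compound 3 to compound 4 (within the scatter), a small rise that would stay within the scatter. For compound 4 the estimated value in this assay is 30%, with an expected range from 10% to 65%.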

Compound 4, oral bioavailability: 10%
The estimate for compound 4 lay 20 percentage points above the measured number; measured number inside the range.
By their numbers in this assay, from the lowest: compounds 4, 2 and 3 (each within the scatter of the next, the first and the last beyond it); then compound 1.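

In this assay, within the data shown here, the swap of 1-hydroxyethyl for pyrazin-2-yl on an aromatic carbon, between two ring nitrogen atoms, gives a number 12 percentage points lower from compound 3 to compound 4 (beyond the scatter) and is the first change in this set that can be read on its own, since the rest of the structure stays the same. It shows that this position is not indifferent to what it carries: a group with no ring and 3 heavy atoms, including 1 hydrogen-bond donor, gives way to a six-membered aromatic ring with 6 heavy atoms and 0 hydrogen-bond donors, and a smaller share of the oral dose reaches the circulation, although the step is modest. No measurement available here explains why the number falls with this change.

A single pair cannot tell whether the fall follows the added ring, the larger size or the missing hydrogen-bond donor, and a simple amine, a carboxylic acid or a longer chain on the same aromatic carbon could help separate these readings. As far as these compounds go, it also remains open whether the same swap would have a similar effect on the core of compound 1.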